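Moving the Fluorine Around the Benzyl Ring

The source may hold more compounds than are shown below. What is called first, only, known or untested is meant among the compounds shown, and "the series" means these compounds.

Three compounds share one core and differ only in the aromatic ring attached to the saturated chain carbon bound to an amine nitrogen in a ring. Compound 1 `O=c1oc2ccccc2n1CC1CCN(Cc2ccccc2Cl)CC1` gives 61 nM in an assay on membranes from liver for displacement of a labelled ligand from Sigma non-opioid intracellular receptor 1 (Rattus norvegicus); on this read-out higher numbers stand for weaker inhibition and lower numbers for stronger inhibition. Compound 2 `O=c1oc2ccccc2n1CC1CCN(Cc2ccc(Cl)cc2Cl)CC1` gives 258 nM. Compound 3 `O=c1oc2ccccc2n1CC1CCN(Cc2ccccc2F)CC1` gives 23 nM, the lowest of the three numbers and thus the strongest inhibition seen so far; its nearest neighbour is compound 1, with a 2.7-fold lower number from compound 1 to compound 3 (0.42 log units; beyond the scatter) when read in the other direction, and the step of an 11-fold lower number from compound 2 to compound 3 (1.05 log units; beyond the scatter) is the largest of the set.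

Compound 4 `O=c1oc2ccccc2n1CC1CCN(Cc2ccc(F)cc2)CC1` keeps every atom and changes only where the fluorine sits: 4-fluorophenyl in place of 2-fluorophenyl on a saturated chain carbon bound to an amine nitrogen in a ring. Among the compounds with values here, no measured pair tests exactly this move, so the comparison is indirect. The step of a 4.2-fold higher number from compound 1 to compound 2 (0.63 log units; beyond the scatter) shows that where substituents stand on this ring changes the number beyond the scatter, while the step of a 2.7-fold lower number from compound 1 to compound 3 (0.42 log units; beyond the scatter) shows that fluorine on this ring can strengthen inhibition relative to chlorine.

On this basis a modest weakening is expected for compound 4, estimated as a 2.4-fold higher number from compound 3 to compound 4 (0.38 log units; beyond the scatter), giving an expected value of 55 nM with a likely range from 18 nM to 170 nM.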

Compound 4, inhibition constant: 3.9 nM
Compound 4: middle estimate off by 14-fold (1.15 log units), on the high side; measured number outside the range, below it.
By their numbers in this assay, from the lowest: compound 4; then compound 3; then compound 1; then compound 2.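

With the same atoms joined differently, moving the fluorine from 2-fluorophenyl to 4-fluorophenyl on the saturated chain carbon bound to an amine nitrogen in a ring strengthens inhibition in this assay (a 5.9-fold lower number from compound 3 to compound 4 (0.77 log units; beyond the scatter)), so the place of this one atom matters on its own, not only the choice of halogen. Compound 4 now has the lowest number of the four, and its steps from the two chlorine compounds are large (a 16-fold lower number from compound 1 to compound 4 (1.19 log units; beyond the scatter); a 66-fold lower number from compound 2 to compound 4 (1.82 log units; beyond the scatter)), yet compound 2 also carries a halogen at the 4 position of its 2,4-dichlorophenyl ring and has the highest number, so a halogen there does not by itself give strong inhibition. Nothing available here explains why the fluorine gives a lower number in its new place.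

On these data alone, it remains open whether a plain phenyl ring, or a nitrile or methoxy group in place of the fluorine of compound 4, would give a similar number. These compounds also leave open how a longer chain in place of the saturated chain carbon bound to the amine nitrogen would change inhibition.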